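Bromo in place of methoxy on the fused ring

The source may report more compounds than this note shows. Statements on the series, on what has been measured and on what is new or still open speak of the compounds shown alone.

Compound 1 `COc1ccc(NC(=O)c2csc(-c3cn(Cc4ccc(Cl)cc4)c4ccccc34)n2)cc1` — > 100000 nM
Compound 2 `O=C(Nc1ccccc1)c1csc(-c2cn(Cc3ccc(Cl)cc3)c3ccccc23)n1` — 24300 nM
Compound 3 `COc1ccc2[nH]cc(-c3nc(C(=O)Nc4cc(OC)c(OC)c(OC)c4)cs3)c2c1` — 29600 nM
Compound 4 `COc1cc(NC(=O)c2csc(-c3c[nH]c4ccc(Br)cc34)n2)cc(OC)c1OC` — not yet measured

The three measured compounds share a core and were tested in a functional assay on HeLa cells (Homo sapiens) for cytotoxicity, read by MTT assay, with a stated time of 48 h, in the absence of a further agent; a higher number here means a weaker inhibitor, a lower number a stronger inhibitor. Compound 1 gives only a limit, > 100000 nM, not a number. Compound 2 gives 24300 nM. Compound 3 gives 29600 nM, the higher of the two numbers, but its gap to compound 2 lies within the scatter, so the two cannot be ranked.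

Compound 4 differs from compound 3 in one place: bromo in place of methoxy on an aromatic carbon. Among the compounds with values here, the only measured step that touches a methoxy group is an at least 4.1-fold lower number from compound 1 to compound 2 (0.61 log units; beyond the scatter), where removing a methoxy from the amide-side aromatic ring brought the number down by at least a modest amount. That change sits on a different ring and removes the group rather than exchanging it for bromo, so it bears on the present step only loosely. Compound 4 is therefore expected to move within or slightly beyond the scatter, with the direction uncertain, a step of a 1.3-fold lower number from compound 3 to compound 4 (0.13 log units; within the scatter). The expected value for compound 4 is 22000 nM, with a range from 7000 nM to 80000 nM.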

Compound 4, half-maximal inhibitory concentration: 55800 nM
Beside the measured number, compound 4's estimate is 2.5-fold (0.40 log units) below it; measured number inside the range.
By their numbers in this assay, from the lowest: compounds 2, 3 and 4 (each within the scatter of the next, the first and the last beyond it). At a limit, above all of these: compound 1.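

In this assay, exchanging methoxy for bromo on this aromatic carbon of the six-membered ring gives a 1.9-fold higher number from compound 3 to compound 4 (0.28 log units; within the scatter), so the pair cannot be ranked. Within the data shown here, this is the first reading at this position, and it shows that a methoxy, with its hydrogen-bond acceptor, can give way to a single bromine atom without a shift beyond the scatter. Compound 1 remains the only one at a limit, which is not a number: the limit of > 100000 nM in this assay, at which 1 of the 4 values shown sits.

The compounds shown leave open how an amine or a carboxylic acid on this same aromatic carbon would read in this assay. They also leave open whether any group at this position can move the number beyond the scatter.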